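The source may hold more compounds than are shown below. What is called first, only, known or untested is meant among the compounds shown, and "the series" means these compounds.

Working notes on a small thiosemicarbazide series of 2-pyridyl amidrazones, read in a functional assay on A-375 cells (Homo sapiens) for cytotoxicity, read by MTT assay, with a stated time of 72 h, tested at 1 uM; on this read-out higher numbers stand for more inhibition of growth at the one concentration tested and lower numbers for less inhibition of growth.

Compound 1 `N/C(=N\NC(=S)N1CCOCC1)c1ccccn1` carries a morpholin-4-yl on the thiocarbonyl carbon; in this assay compound 1 gives 26.8%. Compound 2 `N/C(=N\NC(=S)N1CCCCC1)c1ccccn1` differs only by piperidin-1-yl in place of morpholin-4-yl on a thiocarbonyl carbon, and in this assay compound 2 gives 72.5%. The step of a number 45.7 percentage points higher from compound 1 to compound 2 (beyond the scatter) is the only large move in the set so far.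

Compound 3 `Cc1cccc(/C(N)=N/NC(=S)N2CCOCC2)n1` keeps the morpholin-4-yl and differs from compound 1 by methyl in place of hydrogen on an aromatic carbon; in this assay compound 3 gives 30.2%, and the step of a number 3.4 percentage points higher from compound 1 to compound 3 (within the scatter) shows that the methyl on the ring alone leaves the read-out essentially where it was.

Compound 4 `Cc1cccc(/C(N)=N/NC(=S)N2CCCCC2)n1` is not yet measured. It differs from compound 3 by piperidin-1-yl in place of morpholin-4-yl on a thiocarbonyl carbon, which is the same change as that from compound 1 to compound 2, at a place described in the same words in both pairs; the two cores differ by methyl in place of hydrogen on an aromatic carbon.

Because a number 45.7 percentage points higher from compound 1 to compound 2 (beyond the scatter) was large, and because a number 3.4 percentage points higher from compound 1 to compound 3 (within the scatter) shows the methyl to be neutral on the morpholine pair, the expected step for compound 4 is a number 43.8 percentage points higher from compound 3 to compound 4 (beyond the scatter). Compound 4 is therefore expected to give about 74%, estimated between 55% and 88%.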

Compound 4, percent growth inhibition at one concentration: 49.9%
For compound 4 the middle estimate is 24.1 percentage points above the measured one; measured number outside the range, below it.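

In this assay, piperidin-1-yl in place of morpholin-4-yl on a thiocarbonyl carbon still raises the number on the methyl-bearing core, a number 19.7 percentage points higher from compound 3 to compound 4 (beyond the scatter), so the direction of the change carries over from one core to the other, but its size does not: the same change on two cores in this assay, a number 45.7 percentage points higher (beyond the scatter) from compound 1 to compound 2 and a number 19.7 percentage points higher (beyond the scatter) from compound 3 to compound 4, 26 percentage points apart, beyond the scatter of two such steps

Methyl in place of hydrogen on an aromatic carbon likewise does not behave alike in the two pairs, and on the piperidine pair it gives a number 22.6 percentage points lower from compound 2 to compound 4 (beyond the scatter): the same change on two cores in this assay, a number 3.4 percentage points higher (within the scatter) from compound 1 to compound 3 and a number 22.6 percentage points lower (beyond the scatter) from compound 2 to compound 4, 26 percentage points apart, beyond the scatter of two such steps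

The two changes therefore do not simply add up across these four compounds, so a step taken from one core is a poor guide to its size on the other, though these two pairs show neither why this happens nor whether the direction would hold on any further core.

On these data alone, it remains open whether the loss on the piperidine pair is particular to methyl or would also appear with an ethyl or a chloro on the same aromatic carbon. As far as these compounds go, it is equally open how pyrrolidin-1-yl or 4-methylpiperazin-1-yl on the thiocarbonyl carbon would read on either core.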